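A few compounds are considered here, and "the series" means these few. Any claim that something is new, unique, unknown or untested is made for them only; others in the source may bear on it.

Two compounds share one core and differ only in the aromatic group that sits on a saturated chain carbon bound to a carbonyl carbon. Compound 1 `CCOc1ncc(-c2nc(C(F)(F)F)sc2N2CCN(C(=O)Cn3ncc4cccnc43)[C@H](C)C2)cn1` carries the larger of the two groups; in an assay on blood for inhibition of C-X-C chemokine receptor type 3 (Homo sapiens), with a stated time of 30 min (a lower number here means a stronger inhibitor, a higher number a weaker inhibitor), compound 1 gives 372 nM. Compound 2 `CCOc1ncc(-c2nc(C(F)(F)F)sc2N2CCN(C(=O)Cn3nc(C)cc3C)[C@H](C)C2)cn1` carries a smaller group at the same place, and in this assay compound 2 gives 60 nM. Going by the values given here, the change from the larger to the smaller group is a 6.2-fold lower number from compound 1 to compound 2 (0.79 log units; beyond the scatter), so compound 2 stands as the lower of the two numbers measured so far, with compound 1 as its only neighbour.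

Compound 3 `CCOc1ncc(-c2nc(C(F)(F)F)sc2N2CCN(C(=O)Cn3cc(Cl)cn3)[C@H](C)C2)cn1` keeps the core and changes the same position again: 4-chloro-1H-pyrazol-1-yl in place of 3,5-dimethyl-1H-pyrazol-1-yl on a saturated chain carbon bound to a carbonyl carbon. Among the compounds with values here, the only step that bears on this change is the one from compound 1 to compound 2, which also swapped the aromatic group at this position and was a 6.2-fold lower number from compound 1 to compound 2 (0.79 log units; beyond the scatter). That single step shows the position tolerates exchange but gives no direction for this particular swap. The expectation is therefore a step of a 1.7-fold higher number from compound 2 to compound 3 (0.22 log units; within the scatter), with compound 3 expected at 100 nM, between 30 nM and 350 nM.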

Compound 3, half-maximal inhibitory concentration: 245 nM
Compound 3: middle estimate off by 2.5-fold (0.39 log units), on the low side; the range from low to high includes it.
By their numbers in this assay, from the lowest: compound 2; then compounds 3 and 1 (each within the scatter of the next).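

Keeping a five-membered aromatic ring with 2 hetero atoms, and the same counts of hydrogen-bond donors and acceptors, does not hold the number steady at this position: replacing 3,5-dimethyl-1H-pyrazol-1-yl with 4-chloro-1H-pyrazol-1-yl gives a 4.1-fold higher number from compound 2 to compound 3 (0.61 log units; beyond the scatter) in this assay. The earlier step could have suggested that a smaller group on the saturated chain carbon simply gives a lower number, but compound 3 goes against that, since it carries the smallest group of the three and still shows only a 1.5-fold lower number from compound 1 to compound 3 (0.18 log units; within the scatter). Nothing measured here explains why the two pyrazole groups differ.

This swap removes both methyl groups and adds a chlorine in one move, so the compounds shown leave open whether losing the methyl groups, gaining the chlorine, or both account for the step. The unsubstituted 1H-pyrazol-1-yl group and 4-chloro-3,5-dimethyl-1H-pyrazol-1-yl, which carries both methyl groups and the chlorine, are not among these compounds, and either would help separate those parts of the change.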